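Amino-to-chloro swap on the shared core, growth inhibition

This account rests on a few compounds, and the source may have more. Where it says the series, first, only, none or still open, it means among the compounds named here.

Two compounds on this core have been run in a functional assay on 786-0 cells (Homo sapiens) for cytotoxicity, read by sulforhodamine B assay, with a stated time of 48 h; on this read-out higher numbers stand for weaker inhibition of growth and lower numbers for stronger inhibition of growth. Compound 1 `Nc1nc(Cl)c2ncn(Cc3ccccc3CCl)c2n1` gives 52500 nM and stands as the higher of the two numbers. For the measured compounds named here, compound 2 `ClCc1ccccc1Cn1cnc2ncnc(Cl)c21` gives 12900 nM in this assay, the lower number, with a gap to compound 1 that lies beyond the scatter; no step between these two is worked out here, so only the two values themselves are taken as read.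

Compound 3 `ClCc1ccccc1Cn1cnc2c(Cl)nc(Cl)nc21` is the next compound, not yet measured in this assay. From compound 1 it differs by chloro in place of amino on an aromatic carbon, the place being an aromatic carbon of a six-membered aromatic ring with two nitrogen, between two ring nitrogen atoms, meta to a chloro group.

Going by the values given here, no measured step covers this change. Because compound 2 sits at 12900 nM while compound 1 sits at 52500 nM, a move toward the lower number is expected for compound 3 in this assay, roughly a 3.5-fold lower number from compound 1 to compound 3 (0.54 log units; beyond the scatter), though it may also stay within the scatter. Compound 3 is estimated at 15000 nM, with a range from 5000 nM to 45000 nM.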

Compound 3, concentration for total growth inhibition: 3470 nM
Compound 3: middle estimate off by 4.3-fold (0.64 log units), on the high side, and the stated range ends above it.
By their numbers in this assay, from the lowest: compound 3; then compound 2; then compound 1.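

In this assay, for the compounds shown here, the first measured change at this position, on an aromatic carbon between two ring nitrogen atoms, is chloro in place of amino, and it gives a 15-fold lower number from compound 1 to compound 3 (1.18 log units; beyond the scatter) on the shared core. The three values now fall in one order across this place: compound 1 gives 52500 nM with amino, compound 2 gives 12900 nM with neither group, and compound 3 gives 3470 nM with chloro. No measurement at hand bears on what lies behind this step.

The compounds shown leave open whether bromo, methoxy or methylamino at this place would fit the same order. They also leave open whether the step from amino to chloro holds when the chloromethyl group elsewhere on the molecule gives way to a plain methyl group.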